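The source may hold more compounds than are shown below. What is called first, only, known or untested is meant among the compounds shown, and "the series" means these compounds.

In an assay on CHO cells for displacement of a labelled ligand from adenosine receptor A2b (Homo sapiens), read by scintillation counting, with a stated time of 75 min (a higher number here means a weaker inhibitor, a lower number a stronger inhibitor), compound 1 `O=C(CCc1ccccc1)Nc1nc2ccccc2c(=O)s1` gives 365 nM, and compound 2 `COc1cccc(CCC(=O)Nc2nc3ccccc3c(=O)s2)c1` gives 225 nM, the step of a 1.6-fold lower number from compound 1 to compound 2 (0.21 log units; within the scatter) staying within the scatter. Compound 3 `O=C(CCCc1ccccc1)Nc1nc2ccccc2c(=O)s1` returns only a limit of the assay, > 1000 nM, so it sits at the limit of > 1000 nM in this assay, at which 1 of the 3 values shown sits, and has no number of its own. The steps of an at least 2.7-fold higher number from compound 1 to compound 3 (0.43 log units; beyond the scatter) and an at least 4.4-fold higher number from compound 2 to compound 3 (0.64 log units; beyond the scatter) both run toward weaker inhibition. Compound 4 `O=C(CCc1ccccc1F)Nc1nc2ccccc2c(=O)s1` differs from compound 3 by 2-fluorophenyl in place of benzyl on a saturated chain carbon, two bonds along the chain from a carbonyl carbon. This change undoes the lengthening of the chain, so in this assay the step of an at least 3.3-fold lower number from compound 3 to compound 4 (0.52 log units; beyond the scatter) is expected to run back toward the number seen for compound 1. Compound 4 is therefore estimated at 300 nM, with a range from 120 nM to 900 nM.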

Compound 4, inhibition constant: 801 nM
For compound 4 the middle estimate is 2.7-fold (0.43 log units) below the measured one; the measured number falls inside the stated range.
By their numbers in this assay, from the lowest: compounds 2 and 1 (each within the scatter of the next); then compound 4. At a limit, above all of these: compound 3.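

Fluoro in place of hydrogen on an aromatic carbon gives a 2.2-fold higher number from compound 1 to compound 4 (0.34 log units; beyond the scatter), the first change on this aromatic ring to go beyond the scatter, and 2-fluorophenyl in place of 3-methoxyphenyl gives a 3.6-fold higher number from compound 2 to compound 4 (0.55 log units; beyond the scatter). So the ring is not indifferent to what it carries, although the methoxy step stayed within the scatter. The step of an at least 1.2-fold lower number from compound 3 to compound 4 (0.09 log units; that floor lies within the scatter) gives only a floor, because one end of it is a limit of the assay: the limit of > 1000 nM in this assay, at which 1 of the 4 values shown sits.

On these data alone, how a chloro, hydroxyl or amine group on this ring would fare remains open, as does a chain shorter than that of compound 1.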